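The source may report more compounds than this note shows. Statements on the series, on what has been measured and on what is new or still open speak of the compounds shown alone.

Two compounds share one core and differ only in the aromatic group attached to a carbonyl carbon. Compound 1, with the structure `C[C@@]1(c2cc(NC(=O)c3coc(CF)n3)ccc2F)C=C(CF)OC(N)=N1`, carries a 2-(fluoromethyl)-1,3-oxazol-4-yl there. In an ADME assay on the whole organism (strain Sprague-Dawley) for pharmacokinetics, with Rattus norvegicus as the target, read by LC-MS, using cassette dosing, at a dose of 0.5 mg/kg by the intravenous route (on this read-out lower numbers stand for slow clearance and higher numbers for fast clearance), compound 1 gives 55 mL/min/kg. Compound 2, with the structure `C[C@@]1(c2cc(NC(=O)c3cnc(C(F)F)cn3)ccc2F)C=C(CF)OC(N)=N1`, carries a 5-(difluoromethyl)pyrazin-2-yl in the same place, and in this assay compound 2 gives 48.1 mL/min/kg. The step of a 1.1-fold lower number from compound 1 to compound 2 (0.06 log units; within the scatter) shows that exchanging one aromatic group for another at this carbonyl carbon left the read-out essentially unchanged, so compound 2 and compound 1 cannot be told apart on these numbers.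

Compound 3, with the structure `COc1cc(C#N)cnc1C(=O)Nc1ccc(F)c([C@]2(C)C=C(CF)OC(N)=N2)c1`, is not yet measured. It differs from compound 2 in one place: 5-cyano-3-methoxypyridin-2-yl in place of 5-(difluoromethyl)pyrazin-2-yl on a carbonyl carbon. Going by the values given here, the only measured step that bears on this change is the one already described, another exchange of the aromatic group at the same carbonyl carbon. Because the step of a 1.1-fold lower number from compound 1 to compound 2 (0.06 log units; within the scatter) stayed within the scatter, the step of a 1.1-fold lower number from compound 2 to compound 3 (0.03 log units; within the scatter) is expected to stay within the scatter as well, with no clear direction. Compound 3 is therefore estimated at 45 mL/min/kg, with a range from 22 mL/min/kg to 90 mL/min/kg.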

Compound 3, clearance: 36.6 mL/min/kg
Compound 3: middle estimate off by 1.2-fold (0.09 log units), on the high side; measured number inside the range.
By their numbers in this assay, from the lowest: compounds 3, 2 and 1 (each within the scatter of the next).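

In this assay, the step of a 1.3-fold lower number from compound 2 to compound 3 (0.12 log units; within the scatter) and the step of a 1.5-fold lower number from compound 1 to compound 3 (0.18 log units; within the scatter) both show that a third aromatic group on this carbonyl carbon, the 5-cyano-3-methoxypyridin-2-yl, still leaves the read-out within the scatter. This group differs from the earlier two in carrying a nitrile and a methoxy group and no fluorine at all, so the fluorine-bearing groups of compound 1 and compound 2 are not needed at this position to keep the number within the scatter of theirs. Nothing given here explains why such different groups yield numbers so hard to separate.

Going by these compounds, all three groups at this carbonyl carbon are aromatic rings, so it remains open whether a group without such a ring, for instance a cyclohexyl ring or a short chain ending in an amine or a carboxylic acid, would also stay within the scatter or would give a clearly different number. The shared core is the same in all three compounds, so these results say nothing about how a change elsewhere in the molecule would affect the read-out.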